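The source may report more compounds than this note shows. Statements on the series, on what has been measured and on what is new or still open speak of the compounds shown alone.

In a functional assay on OVCAR-8 cells (Homo sapiens) for antiproliferative activity (a lower number here means a stronger inhibitor, a higher number a weaker inhibitor), compound 1 `CNC(=O)C[C@@H]1C[C@@H](c2ccc(Cl)c(Cl)c2)[C@H](NC(=O)c2cc(-c3c(Cl)cnn3C)c(Cl)o2)CN1` gives 1130 nM and compound 2 `Cn1ncc(Cl)c1-c1cc(C(=O)N[C@@H]2CN[C@H](CCO)C[C@H]2c2ccc(F)c(F)c2)oc1Cl` gives 460 nM. Compound 3 `CC(=O)NCC[C@@H]1C[C@@H](c2ccc(F)c(F)c2)[C@H](NC(=O)c2cc(-c3c(Cl)cnn3C)c(Cl)o2)CN1` gives 880 nM, which lies within the usual scatter of both other compounds. Going on to compound 4 `CNC(=O)C[C@@H]1C[C@@H](c2ccc(F)c(F)c2)[C@H](NC(=O)c2cc(-c3c(Cl)cnn3C)c(Cl)o2)CN1`, methylcarbamoyl takes the place of acetamidomethyl on a saturated chain carbon bound to a saturated ring carbon: methylcarbamoyl in place of acetamidomethyl on a saturated chain carbon bound to a saturated ring carbon. Cut one bond further out, the same difference reads 2-acetamidoethyl to (methylcarbamoyl)methyl.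

For the measured compounds named here, only one measured step alters this side chain, and it is small: a 1.9-fold higher number from compound 2 to compound 3 (0.28 log units; within the scatter), with acetamido in place of hydroxy. Compound 1 also carries the methylcarbamoyl group, and its 1130 nM is close to the value of compound 3. The new change leaves the counts of hydrogen-bond donors and acceptors as they were, so no step beyond the scatter is expected in this assay. The expected change is a 1.0-fold higher number from compound 3 to compound 4 (0.01 log units; within the scatter). Compound 4 is estimated at 900 nM, with an expected range from 480 nM to 1700 nM.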

Compound 4, half-maximal inhibitory concentration: 800 nM
Beside the measured number, compound 4's estimate is 1.1-fold (0.05 log units) above it; low and high end bracket the measured number.
By their numbers in this assay, from the lowest: compounds 2, 4, 3 and 1 (each within the scatter of the next, the first and the last beyond it).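

In this assay, the two steps that replace a group on a saturated chain carbon bound to a saturated ring carbon both stay within the scatter: methylcarbamoyl in place of acetamidomethyl (a 1.1-fold lower number from compound 3 to compound 4 (0.04 log units; within the scatter)) and methylcarbamoyl in place of hydroxymethyl (a 1.7-fold higher number from compound 2 to compound 4 (0.24 log units; within the scatter)). Through these steps, hydroxymethyl, acetamidomethyl and methylcarbamoyl cannot be told apart at this place, even though the amide in compound 4 differs from that in compound 3 in how it is attached. Compound 4 also gives a direct reading of the halogens on the aromatic ring, with 3,4-difluorophenyl in place of 3,4-dichlorophenyl on a saturated ring carbon (a 1.4-fold lower number from compound 1 to compound 4 (0.15 log units; within the scatter)), and this too lies within the scatter.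

Nothing available explains why these groups read alike. From the compounds shown here alone, whether an amine, a carboxylic acid or a longer chain at this place would give a step beyond the scatter remains open.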